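A few compounds are considered here, and "the series" means these few. Any claim that something is new, unique, unknown or untested is made for them only; others in the source may bear on it.

Among the measured compounds shown here, compound 1 `O=C(/C=C/c1ccc2c(c1)B(O)OC2)c1ccccc1` gives 3400 nM in a functional assay on SK-OV-3 cells (Homo sapiens) for cytotoxicity, read by MTT assay, with a stated time of 48 h (a higher number here means a weaker inhibitor, a lower number a stronger inhibitor), which places it second highest of the three numbers measured so far. Compound 3 `Cc1cccc(C(=O)/C=C/c2ccc3c(c2)B(O)OC3)c1` gives 2900 nM in this assay, and compound 2 `O=C(/C=C/c1ccc2c(c1)B(O)OC2)c1ccco1` gives 20700 nM. The steps between them run a 1.2-fold lower number from compound 1 to compound 3 (0.07 log units; within the scatter), a 6.1-fold higher number from compound 1 to compound 2 (0.78 log units; beyond the scatter) and a 7.1-fold lower number from compound 2 to compound 3 (0.85 log units; beyond the scatter). Compound 4 `O=C(/C=C/c1ccc2c(c1)B(O)OC2)c1cccc(O)c1` differs from compound 1 by hydroxy in place of hydrogen on an aromatic carbon.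

For the measured compounds named here, the one measured step that bears directly on this change is the one from compound 1 to compound 3, where a methyl enters at an aromatic carbon of the same phenyl and the number moves a 1.2-fold lower number from compound 1 to compound 3 (0.07 log units; within the scatter), within the scatter. The step from compound 1 to compound 2 exchanges the whole ring on the carbonyl carbon and says little about a single substituent on the phenyl. Going by the values given here, no measured step shows a hydroxy entering anywhere, so the expectation rests on the methyl step alone: no change beyond the scatter in this assay, in either direction.

Compound 4 is therefore expected to give about 3000 nM in this assay, within 1200 nM to 7500 nM. That estimate means a step of a 1.1-fold lower number from compound 1 to compound 4 (0.05 log units; within the scatter).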

Compound 4, half-maximal inhibitory concentration: 3800 nM
Compound 4: middle estimate off by 1.3-fold (0.10 log units), on the low side; low and high end bracket the measured number.
By their numbers in this assay, from the lowest: compounds 3, 1 and 4 (each within the scatter of the next); then compound 2.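

Hydroxy in place of hydrogen on this aromatic carbon brings the first hydrogen-bond donor onto the phenyl, and in this assay the result is a 1.1-fold higher number from compound 1 to compound 4 (0.05 log units; within the scatter). Hydroxy in place of methyl at the same place gives a 1.3-fold higher number from compound 3 to compound 4 (0.12 log units; within the scatter), so two different groups here now leave the number within the scatter of the unsubstituted phenyl, while 3-hydroxyphenyl in place of furan-2-yl gives a 5.4-fold lower number from compound 2 to compound 4 (0.74 log units; beyond the scatter), keeping the furan-2-yl compound apart from all three phenyl compounds. No measured data on the series speak to the reason for this flat reading.

From the compounds shown here alone, whether it holds for an amine, a carboxylic acid or a longer chain at this place remains open. So does whether hydroxy reads the same on the other carbons of the phenyl.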